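This account rests on a few compounds, and the source may have more. Where it says the series, first, only, none or still open, it means among the compounds named here.

Of the compounds shown here, two built on a shared core have been measured so far. In a functional assay on MCF7 cells (Homo sapiens) for cytotoxicity, read by MTT assay, with a stated time of 96 h (a lower number here means a stronger inhibitor, a higher number a weaker inhibitor), compound 1 `COc1cc(C(=O)c2cn(-c3ccc(Cl)cc3)cc2-c2ccccc2)cc(OC)c1OC` gives 140 nM and compound 2 `COc1cc(C(=O)c2cn(-c3ccccc3)cc2-c2ccccc2Cl)cc(OC)c1OC` gives 76 nM. These two values lie within the usual scatter of each other, so the numbers do not separate compound 2 from compound 1.

Compound 3 `COc1cc(C(=O)c2cn(-c3ccccc3)cc2-c2ccc(Br)cc2)cc(OC)c1OC` has 4-bromophenyl in place of the 2-chlorophenyl of compound 2, on an aromatic carbon (4-bromophenyl in place of 2-chlorophenyl on an aromatic carbon). Among the compounds with values here, no measured pair differs in one place only, and no measured compound carries the 4-bromophenyl group, so the data give no direct guide to this change. Within the data shown here, the only guide is the narrow spread of the two values, compound 1 at 140 nM and compound 2 at 76 nM.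

In this assay, the expected change is a 1.3-fold higher number from compound 2 to compound 3 (0.12 log units; within the scatter), a slight move toward a higher number and none beyond the scatter. For compound 3, the estimated value is 100 nM, with an expected range from 30 nM to 350 nM.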

Compound 3, half-maximal inhibitory concentration: 340 nM
The estimate for compound 3 lay 3.4-fold (0.53 log units) below the measured number; the range from low to high includes it.
By their numbers in this assay, from the lowest: compounds 2 and 1 (each within the scatter of the next); then compound 3.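

In this assay, within the data shown here, this is the first step that can be read at all, and it falls on the aromatic carbon two ring bonds from the ring nitrogen: 4-bromophenyl in place of 2-chlorophenyl gives a 4.5-fold higher number from compound 2 to compound 3 (0.65 log units; beyond the scatter), which lies beyond the scatter. The position therefore responds to a change in its aryl group, which the two earlier compounds could not show, since they differ in more than one place. The step appears even though the two groups match in every count computed here, with the same number of heavy atoms, one six-membered aromatic ring of carbon only, no hydrogen-bond donors or acceptors and no net charge, and nothing measured in the material shown explains the difference.

The change alters both the halogen and its place on the phenyl ring, so the compounds shown cannot tell which of the two accounts for the step. A 2-bromophenyl or a 4-chlorophenyl group at this position would separate them, while a 4-methoxyphenyl or 4-aminophenyl group would show whether a non-halogen substituent is tolerated there.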